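Methyl for Methoxy on the Outer Ring of Compound 1

This account rests on a few compounds, and the source may have more. Where it says the series, first, only, none or still open, it means among the compounds named here.

Measured compounds:
compound 1, `COc1cccc(-c2noc(C3CC(=O)N(c4ccc(Cl)cc4)C3)n2)c1`: 4800 nM
compound 2, `O=C1CC(c2nc(-c3ccccn3)no2)CN1c1ccc(F)cc1`: > 10000 nM (a limit)
compound 3, `O=C1CC(c2nc(-c3ccccc3)no2)CN1c1ccc(F)cc1`: 58 nM

In an in vitro functional assay on HEK293-A cells for positive allosteric modulation of metabotropic glutamate receptor 5 (Homo sapiens), read by FLIPR and calcium flux (on this read-out higher numbers stand for an effect only at larger amounts of compound and lower numbers for an effect already at smaller amounts), compound 1 gives 4800 nM, the highest of the two numbers shown. Compound 3 gives 58 nM, a lower number. For compound 2 the assay reports only a limit, > 10000 nM. Among the measured compounds shown here, the single one-place step among the measured compounds is an at least 170-fold lower number from compound 2 to compound 3 (2.23 log units; beyond the scatter), a change of the whole ring hanging on the shared core, and it starts from the limit of > 10000 nM in this assay, at which 1 of the 3 values shown sits.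

Compound 4, `Cc1cccc(-c2noc(C3CC(=O)N(c4ccc(Cl)cc4)C3)n2)c1`, differs from compound 1 by methyl in place of methoxy on an aromatic carbon. No measured step concerns this change: the one step shown, an at least 170-fold lower number from compound 2 to compound 3 (2.23 log units; beyond the scatter), swaps one ring for another rather than altering a small group on a ring. The data therefore give no ground to expect a step beyond the scatter in this assay from compound 1 to compound 4. The expected step is a 1.1-fold lower number from compound 1 to compound 4 (0.03 log units; within the scatter). Compound 4 is thus estimated at 4500 nM, with a range from 1500 nM to 13000 nM.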

Compound 4, half-maximal effective concentration: 170 nM
For compound 4 the middle estimate is 26-fold (1.42 log units) above the measured one; measured number below the stated range.
By their numbers in this assay, from the lowest: compound 3; then compound 4; then compound 1. At a limit, above all of these: compound 2.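

Replacing the methoxy of the 3-methoxyphenyl group with a methyl is a small edit, yet in this assay it gives a 28-fold lower number from compound 1 to compound 4 (1.45 log units; beyond the scatter) and leaves the rest of the molecule untouched. Among the compounds shown here, the earlier step changed a whole ring, so only this new step shows that a single small group at this place on the outer ring can move the number by a large amount. Nothing shown here explains why this one change has so large an effect.

From the compounds shown here alone, it remains open whether the step comes from the methyl itself or from the loss of the oxygen, which a hydroxyl, an amine or an ethyl at the same place could help to separate. Going by these compounds, it is also open whether the same swap would give a step of similar size on a compound with a different ring on the amide nitrogen.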